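Growing the branched alkyl group on the shared core

The source may hold more compounds than are shown below. What is called first, only, known or untested is meant among the compounds shown, and "the series" means these compounds.

Measured so far:
- compound 1, `CC(C)(C)Cc1cnc(CCc2ccc(-c3ccccc3C(=O)O)cc2)[nH]1`: 6.3 nM
- compound 2, `CCCCc1cnc(C(C)Cc2ccc(-c3ccccc3C(=O)O)cc2)[nH]1`: 184 nM

In an in vitro functional assay on cells for agonist activity at Bombesin receptor subtype-3 (Mus musculus), read by luminescence and calcium flux (on this read-out higher numbers stand for an effect only at larger amounts of compound and lower numbers for an effect already at smaller amounts), compound 1 gives 6.3 nM, the lowest of the two numbers available. Compound 2 gives 184 nM, a value that lies well beyond the scatter of repeated measurements and therefore shows a real difference between the two; the two compounds differ in more than one place, so nothing further can be read from that gap.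

Compound 3, `CCC(C)(CC)Cc1cnc(CCc2ccc(-c3ccccc3C(=O)O)cc2)[nH]1`, has not yet been measured in this assay. It differs from compound 1 by 1-ethyl-1-methylpropyl in place of tert-butyl on a saturated chain carbon bound to an aromatic carbon, keeping the rest of the core unchanged. Among the measured compounds shown here, no measured pair shows what such a change does here. The expectation is that the step of a 1.3-fold higher number from compound 1 to compound 3 (0.10 log units; within the scatter) stays small, with no direction beyond the scatter. Compound 3 is therefore estimated at 8 nM, with a range from 2 nM to 30 nM.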

Compound 3, half-maximal effective concentration: 30 nM
The estimate for compound 3 lay 3.8-fold (0.57 log units) below the measured number; the range from low to high includes it.
By their numbers in this assay, from the lowest: compound 1; then compound 3; then compound 2.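

Putting 1-ethyl-1-methylpropyl in place of tert-butyl on the shared core gives a 4.8-fold higher number from compound 1 to compound 3 (0.68 log units; beyond the scatter) in this assay. Among the compounds shown here, this is the first comparison here in which only one place changes, and it shows that this saturated chain carbon bound to an aromatic carbon does not accept the larger branched alkyl group without a cost: more of compound 3 is needed for the same half-maximal effect, although the step is modest. No measurement at hand explains this rise.

A single pair cannot show whether the number climbs steadily as the branched group grows or whether this particular group is the exception. On these data alone, the effect of 1,1-dimethylpropyl, a cyclohexyl ring or a chain ending in an amine at this place remains open.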